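The source may hold more compounds than are shown below. What is called first, only, known or untested is meant among the compounds shown, and "the series" means these compounds.

Measured so far in an assay on HEK293 cells for positive allosteric modulation of metabotropic glutamate receptor 3 (Rattus norvegicus), read by thallium flux, with a stated time of 2.5 min; on this read-out lower numbers stand for an effect already at smaller amounts and higher numbers for an effect only at larger amounts of compound:
- compound 1 `Cc1cc(C(=O)O)ccc1OCCCCOc1ccc(C(=O)CC(C)C)c(O)c1C`: 1850 nM
- compound 2 `Cc1c(OCCCCOc2ccc(C(=O)O)c(Cl)c2)ccc(C(=O)CC(C)C)c1C`: "not determined" (no result reported)
- compound 3 `Cc1c(OCCCCOc2ccc(C(=O)O)c(Cl)c2)ccc(C(=O)CC2CCCC2)c1O`: 2250 nM

Among the measured compounds shown here, compound 3 and compound 1 sit within the scatter of each other in this assay; compound 2 contributes no number, so only two values frame the series. No single-point comparison between measured compounds is available, and the two numbers present differ in several places at once.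

Compound 4 `Cc1c(OCCCCOc2ccc(C(=O)O)c(Cl)c2)ccc(C(=O)CC(C)C)c1O` is the untested member. It differs from compound 3 in one place: isopropyl in place of cyclopentyl on a saturated chain carbon bound to a carbonyl carbon. Compound 1 already carries the isobutylcarbonyl on a different aryl acid, and in this assay compound 1 gives 1850 nM, which is within the scatter of compound 3. The step in this assay is therefore expected to be small, in no settled direction, and not clearly beyond the scatter. The expected step of a 1.1-fold lower number from compound 3 to compound 4 (0.05 log units; within the scatter) is accordingly close to flat. Compound 4 is estimated at 2000 nM, with a range from 900 nM to 4500 nM.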

Compound 4, half-maximal effective concentration: 2050 nM
Estimate against measurement, compound 4: 1.0-fold (0.01 log units) below, within the range that was stated.
By their numbers in this assay, from the lowest: compounds 1, 4 and 3 (each within the scatter of the next).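

In this assay the series now has single-place comparisons: isopropyl in place of cyclopentyl on a saturated chain carbon bound to a carbonyl carbon gives a 1.1-fold lower number from compound 3 to compound 4 (0.04 log units; within the scatter) and does not separate the two compounds, whether the group carries the five-membered ring or no ring. On the aryl acid, 4-carboxy-3-chlorophenyl in place of 4-carboxy-2-methylphenyl on an oxygen on a saturated carbon gives a 1.1-fold higher number from compound 1 to compound 4 (0.04 log units; within the scatter) and likewise does not separate them, so neither exchange moves the number beyond the scatter. No independent measurement bears on why these exchanges stay this flat.

Open, on these data alone, is whether a phenyl ring, a primary amine or a longer chain at the chain carbon would give a step beyond the scatter. The step between compound 2 and compound 4 cannot be read, as compound 2 has no reported result.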